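Amine-linked analogues of the shared core in the kinase assay

The source may report more compounds than this note shows. Statements on the series, on what has been measured and on what is new or still open speak of the compounds shown alone.

Compound 1 `Cn1cc(-c2n[nH]c3ccc(NC4CCNC4)cc23)cn1` gives 132000 nM in an assay on isolated protein for inhibition of tyrosine-protein kinase receptor UFO (Homo sapiens), with a stated time of 1.5 h; a lower number here means a stronger inhibitor, a higher number a weaker inhibitor. Among the three measured compounds it holds the second highest number: compound 3 `Cn1cc(-c2n[nH]c3cc(-c4ccccc4)ccc23)cn1` gives 12300 nM, while compound 2 `CN1CCC(CNc2ccc3[nH]nc(-c4cnn(C)c4)c3c2)CC1` gives 1850000 nM, a step of a 14-fold higher number from compound 1 to compound 2 (1.15 log units; beyond the scatter). Compound 4 `CNC1CCN(c2ccc3[nH]nc(-c4cnn(C)c4)c3c2)C1` differs from compound 1 by 3-(methylamino)pyrrolidin-1-yl in place of (pyrrolidin-3-yl)amino on an aromatic carbon. Within the data shown here, the only measured step that bears on this, the change at the same aromatic carbon from compound 1 to compound 2, was large and toward a higher number, but it altered the amine substituent rather than its mode of attachment, so it guides only loosely. A moderate step toward a weaker inhibitor is expected, a 1.9-fold higher number from compound 1 to compound 4 (0.28 log units; within the scatter). Compound 4 is therefore estimated at 250000 nM, within 60000 nM to 1000000 nM.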

Compound 4, half-maximal inhibitory concentration: 432000 nM
For compound 4 the middle estimate is 1.7-fold (0.24 log units) below the measured one, within the range that was stated.
By their numbers in this assay, from the lowest: compound 3; then compound 1; then compound 4; then compound 2.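

Replacing (pyrrolidin-3-yl)amino with 3-(methylamino)pyrrolidin-1-yl on this aromatic carbon gives a 3.3-fold higher number from compound 1 to compound 4 (0.51 log units; beyond the scatter), so the number here shifts beyond the scatter when the amine is attached through its ring nitrogen, whereas the earlier step of a 14-fold higher number from compound 1 to compound 2 (1.15 log units; beyond the scatter) kept the attachment through the linking nitrogen. This single change also adds a methyl on the amine, and the step cannot separate the two alterations. No supporting data explain the result.

From the compounds shown here alone, whether 3-aminopyrrolidin-1-yl, lacking that methyl, would track compound 1 or compound 4 remains open. Going by these compounds, the effect of a piperazine at this aromatic carbon also remains open.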